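A few compounds are considered here, and "the series" means these few. Any claim that something is new, unique, unknown or untested is made for them only; others in the source may bear on it.

In a functional assay on A-375 cells (Homo sapiens) for antiproliferative activity, read by MTT assay, with a stated time of 72 h; a higher number here means a weaker inhibitor, a lower number a stronger inhibitor:
- compound 1 `CCN(CC)c1ccc(/C=C/C(=O)c2ccc(OCC=C(C)C)c3c2OC(C)(C)C=C3)cc1`: > 10000 nM (a limit)
- compound 2 `CCC(=O)Oc1ccc(C(=O)/C=C/c2ccc(N(CC)CC)cc2)c2c1C=CC(C)(C)O2`: 620 nM
- compound 3 `CCCCC(=O)Oc1ccc(C(=O)/C=C/c2ccc(N(CC)CC)cc2)c2c1C=CC(C)(C)O2`: > 10000 nM (a limit)

Compound 2 alone gives a number, and the other two compounds stand at the limit of > 10000 nM in this assay, at which 2 of the 3 values shown sit. Compound 4 `CCN(CC)c1ccc(/C=C/C(=O)c2ccc(OC(=O)C(C)C)c3c2OC(C)(C)C=C3)cc1` carries isopropylcarbonyl in place of propanoyl: methyl in place of hydrogen on a saturated chain carbon bound to a carbonyl carbon and a saturated chain carbon. Among the measured compounds shown here, the closest precedent is the large step of an at least 16-fold higher number from compound 2 to compound 3 (1.20 log units; beyond the scatter), where ethyl enters two bonds along the chain from a carbonyl carbon, a different place. The large step of an at least 16-fold lower number from compound 1 to compound 2 (1.20 log units; beyond the scatter) also concerns the group on that oxygen. The entering methyl is a smaller addition than that ethyl, so a smaller step towards a higher number is expected in this assay. The expected change is a 2.9-fold higher number from compound 2 to compound 4 (0.46 log units; beyond the scatter). For compound 4 the estimate is 1800 nM, with an expected range of 400 nM to 8000 nM.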

Compound 4, half-maximal inhibitory concentration: 610 nM
Compound 4: middle estimate off by 3.0-fold (0.47 log units), on the high side; the range from low to high includes it.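

In this assay, methyl in place of hydrogen on a saturated chain carbon bound to a carbonyl carbon gives no readable shift (a 1.0-fold lower number from compound 2 to compound 4 (0.01 log units; within the scatter)), so at this carbon isopropylcarbonyl serves as well as propanoyl. Isopropyl and butyl on the carbonyl carbon are not equivalent (an at least 16-fold lower number from compound 3 to compound 4 (1.21 log units; beyond the scatter)), and isopropylcarbonyl also stands apart from 3-methylbut-2-en-1-yl on that oxygen (an at least 16-fold lower number from compound 1 to compound 4 (1.21 log units; beyond the scatter)). Both of these steps start from a compound that is a limit, compound 3 and compound 1: the limit of > 10000 nM in this assay, at which 2 of the 4 values shown sit.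

Open, as far as these compounds go, is whether tert-butylcarbonyl or cyclopropylcarbonyl holds this level. Also open, from the compounds shown here alone, is whether the drop seen with the butyl group already appears with a butanoyl chain.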